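Replacing the thiazole with an aminomethylphenyl group

This account rests on a few compounds, and the source may have more. Where it says the series, first, only, none or still open, it means among the compounds named here.

Compound 1, `COc1ccc(C(=O)Nc2cccc(NC(=O)COc3ccc4c(=O)ccoc4c3)c2)cc1`: in an assay on isolated protein for inhibition of Rho-associated protein kinase 2 (Homo sapiens), read by scintillation counting, radiometric assay and 33P incorporation, with a stated time of 40 min, in the presence of a further agent that is not named here (on this read-out lower numbers stand for stronger inhibition and higher numbers for weaker inhibition), compound 1 gives 7 nM.
Compound 2, `CCOc1ccc(C(=O)Nc2cccc(NC(=O)COc3ccc4c(=O)ccoc4c3)c2)cc1`: in this assay compound 2 gives 9 nM.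
Compound 3, `Cc1nc(C(=O)Nc2cccc(NC(=O)COc3ccc4c(=O)ccoc4c3)c2)cs1`: in this assay compound 3 gives 33 nM.

Compound 3 has the highest number of the three. Compounds 1 and 2 differ only by methyl in place of hydrogen on a saturated chain carbon bound to an oxygen on an aromatic ring, and that step reads a 1.3-fold higher number from compound 1 to compound 2 (0.11 log units; within the scatter). Putting the 2-methyl-1,3-thiazol-4-yl group on the carbonyl carbon in place of the alkoxyphenyl groups raised the number: a 4.7-fold higher number from compound 1 to compound 3 (0.67 log units; beyond the scatter), and a 3.7-fold higher number from compound 2 to compound 3 (0.56 log units; beyond the scatter).

Compound 4, `NCc1ccc(C(=O)Nc2cccc(NC(=O)COc3ccc4c(=O)ccoc4c3)c2)cc1`, is not yet measured. It differs from compound 3 as follows: 4-(aminomethyl)phenyl in place of 2-methyl-1,3-thiazol-4-yl on a carbonyl carbon. The steps from compound 1 and from compound 2 to compound 3 bear on this change, since each of them exchanged a six-membered carbon ring for the thiazole and each raised the number modestly. For the measured compounds named here, compound 4 restores a six-membered carbon ring, although the substituent on it is new and no measured pair shows the aminomethyl group itself. The expectation is therefore a modest fall in this assay, estimated as a 2.8-fold lower number from compound 3 to compound 4 (0.44 log units; beyond the scatter). Compound 4 is expected to give about 12 nM, within a range of 4 nM to 40 nM.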

Compound 4, half-maximal inhibitory concentration: 66 nM
For compound 4 the middle estimate is 5.5-fold (0.74 log units) below the measured one; measured number outside the range, above it.
By their numbers in this assay, from the lowest: compounds 1 and 2 (each within the scatter of the next); then compounds 3 and 4 (each within the scatter of the next).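

Restoring a six-membered carbon ring on the carbonyl carbon does not by itself bring back the low numbers of compound 1 and compound 2: in this assay, the change from the thiazole to the 4-(aminomethyl)phenyl group gives a 2.0-fold higher number from compound 3 to compound 4 (0.30 log units; within the scatter), so these two groups cannot be told apart here. The substituent on the ring makes the clearer difference, since aminomethyl in place of ethoxy gives a 7.3-fold higher number from compound 2 to compound 4 (0.87 log units; beyond the scatter), and aminomethyl in place of methoxy gives a 9.4-fold higher number from compound 1 to compound 4 (0.97 log units; beyond the scatter). Nothing in the data shown explains why aminomethyl on this ring gives a higher number than either ethoxy or methoxy.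

On these data alone, it remains open whether the nitrogen of the amine or the extra carbon chain matters more, a question that a hydroxymethyl group, an ethyl group or a directly attached amine on the same aromatic carbon could help to separate. A longer 2-aminoethyl chain or an acetylated aminomethyl group could likewise show whether the higher number belongs to the free amine itself or to any group of this kind.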